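Predicting a Chloro Analogue in a Cell Growth Assay

This account rests on a few compounds, and the source may have more. Where it says the series, first, only, none or still open, it means among the compounds named here.

Compound 1 `c1ccc(-c2cn3ccnc3c(-c3ccc4ncn(C5CCCCC5)c4c3)n2)cc1` gives 24.2%
Compound 2 `COc1ccc(-c2cn3ccnc3c(-c3ccc4ncn(C5CCCCC5)c4c3)n2)cc1` gives 56.7%
Compound 3 `c1ccc2c(-c3cn4ccnc4c(-c4ccc5ncn(C6CCCCC6)c5c4)n3)cccc2c1` gives 13.3%

All three were measured in a functional assay on EKVX cells (Homo sapiens) for inhibition, read by sulforhodamine B assay, with a stated time of 48 h, tested at 10 uM; on this read-out higher numbers stand for more inhibition at the one concentration tested (going by the name of the read-out) and lower numbers for less inhibition. Compound 1 stands second highest of the three: compound 3 sits a number 10.9 percentage points lower from compound 1 to compound 3 (beyond the scatter), whereas compound 2 sits a number 32.5 percentage points higher from compound 1 to compound 2 (beyond the scatter).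

The unmeasured compound 4 `Clc1ccc(-c2cn3ccnc3c(-c3ccc4ncn(C5CCCCC5)c4c3)n2)cc1` differs from compound 1 in one place: chloro in place of hydrogen on an aromatic carbon. The step most relevant to this change is the one made at the same position, where a methoxy group entering gave a large gain from compound 1 to compound 2. Among the measured compounds shown here, no measured compound carries a chloro group, so that step is only a loose guide, and the ring change from compound 1 to compound 3 points the other way. A modest rise is therefore expected, a number 8.8 percentage points higher from compound 1 to compound 4 (within the scatter). Compound 4 is estimated at 33%, with a range from 15% to 55%.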

Compound 4, a percentage reported as inhibition, at one concentration (the size of the read-out at that concentration, not a potency): 13.1%
The estimate for compound 4 lay 19.9 percentage points above the measured number; the whole stated range lies above it.
By their numbers in this assay, from the lowest: compounds 4 and 3 (each within the scatter of the next); then compound 1; then compound 2.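

Chloro in place of hydrogen gives a number 11.1 percentage points lower from compound 1 to compound 4 (beyond the scatter), so it moves the number the opposite way to methoxy, and the two groups lie far apart at this one position, with a number 43.6 percentage points lower from compound 2 to compound 4 (beyond the scatter) as the step between them. Adding a group at this place therefore does not by itself raise the number. With a number 0.2 percentage points lower from compound 3 to compound 4 (within the scatter) as the step, the 4-chlorophenyl and naphthalen-1-yl compounds cannot be told apart on this read-out.

From the compounds shown here alone, whether an amine or a hydroxyl group in this place would behave like methoxy or like chloro stays open. Nothing measured here offers a reason for the split between chloro and methoxy.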